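The source may hold more compounds than are shown below. What is called first, only, known or untested is meant among the compounds shown, and "the series" means these compounds.

Three compounds share one core and differ only in the group carried on an aromatic nitrogen. Compound 1 `CCc1ccccc1-n1nncc1CN1C(=O)C2(C(C#N)=C(N)Oc3c(N)cc4nc5ccccc5nc4c32)c2ccccc21` gives 10300 nM in a functional assay on HCT-116 cells (Homo sapiens) for antiproliferative activity, read by MTT assay, with a stated time of 48 h; a higher number here means a weaker inhibitor, a lower number a stronger inhibitor. Compound 3 `N#CC1=C(N)Oc2c(N)cc3nc4ccccc4nc3c2C12C(=O)N(Cc1cnnn1-c1ccccc1Br)c1ccccc12` gives 12400 nM in this assay, the highest of the two numbers, though the step of a 1.2-fold higher number from compound 1 to compound 3 (0.08 log units; within the scatter) lies within the scatter. Compound 2 `N#CC1=C(N)Oc2c(N)cc3nc4ccccc4nc3c2C12C(=O)N(Cc1cnnn1-c1ccc(F)cc1)c1ccccc12` reaches only a limit, > 50000 nM. Compound 4 `COc1ccccc1-n1nncc1CN1C(=O)C2(C(C#N)=C(N)Oc3c(N)cc4nc5ccccc5nc4c32)c2ccccc21` differs from compound 3 by methoxy in place of bromo on an aromatic carbon. The step that bears most on it is another swap of a small group on an aromatic carbon, a 1.2-fold higher number from compound 1 to compound 3 (0.08 log units; within the scatter), which changed little; the steps of an at least 4.8-fold higher number from compound 1 to compound 2 (0.68 log units; beyond the scatter) and an at least 4.0-fold lower number from compound 2 to compound 3 (0.60 log units; beyond the scatter) run into the limit of > 50000 nM in this assay, at which 1 of the 3 values shown sits, and say less. The step of a 1.0-fold lower number from compound 3 to compound 4 (0.01 log units; within the scatter) is therefore expected to stay within the scatter. Compound 4 is estimated at 12000 nM, between 5000 nM and 35000 nM.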

Compound 4, half-maximal inhibitory concentration: > 50000 nM
Compound 4: a limit, no number; the forecaster's own chance of this, stated with the estimate: 15%; middle value at least 4.1-fold (0.61 log units) from the limit.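

Bromo and ethyl on this aromatic carbon gave values within the scatter of each other, so the position looked as if it tolerated change, but methoxy shows otherwise, giving an at least 4.0-fold higher number from compound 3 to compound 4 (0.60 log units; beyond the scatter) and an at least 4.8-fold higher number from compound 1 to compound 4 (0.68 log units; beyond the scatter). Methoxy carries a hydrogen-bond acceptor and bromo none, though nothing shown ties the loss to that. The step between compound 2 and compound 4 cannot be read because both values are limits, not numbers: the limit of > 50000 nM in this assay, at which 2 of the 4 values shown sit.

On these data alone, whether a chloro, a methyl, a hydroxyl or an amine in this place would stay with compound 1 and compound 3 or fall away with compound 4 remains open.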